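From 4-nitrophenyl to 2,4-dichlorophenyl on the shared core

This account rests on a few compounds, and the source may have more. Where it says the series, first, only, none or still open, it means among the compounds named here.

Compound 1 `COC(=O)c1c(NCc2ccc(Cl)cc2)noc1-c1ccc([N+](=O)[O-])cc1` gives 78300 nM
Compound 2 `COC(=O)c1c(NCc2ccc(OC)cc2)noc1-c1ccc([N+](=O)[O-])cc1` gives "not determined" (no result reported)
Compound 3 `COC(=O)c1c(NCc2ccc(OC)cc2OC)noc1-c1ccc([N+](=O)[O-])cc1` gives "not determined" (no result reported)

In an ADME assay on J774.A1 cells (Mus musculus) for cytotoxicity, read by MTT assay, with a stated time of 48 h (a higher number here means that more compound is tolerated, a lower number that less compound is tolerated), compound 2 stands without a single number ("not determined" (no result reported)), and compound 3 shares that position ("not determined" (no result reported)). Compound 2 therefore offers no starting value from which to follow a change, and its place in the series cannot be fixed on the numbers available. Of the three, only compound 1 returned a figure (78300 nM), and that figure is the sole anchor for what follows.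

Compound 4 (`COC(=O)c1c(NCc2ccc(OC)cc2)noc1-c1ccc(Cl)cc1Cl`) has yet to be measured. For the measured compounds named here, the single change (2,4-dichlorophenyl in place of 4-nitrophenyl on an aromatic carbon) sets 2,4-dichlorophenyl in place of 4-nitrophenyl on an aromatic carbon, next to the ring oxygen. Going by the values given here, no measured pair in this small set shows what such a change does, so the data give no size or direction for it. The expectation in this assay is therefore a step no larger than the usual scatter, in neither direction, with the result staying in the region of compound 1 (78300 nM). Compound 4 is estimated at 65000 nM (expected range 20000 nM to 200000 nM) in this measurement.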

Compound 4, half-maximal cytotoxic concentration: 34700 nM
For compound 4 the middle estimate is 1.9-fold (0.27 log units) above the measured one; measured number inside the range.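

In this assay, for the compounds shown here, compound 4 gives 34700 nM but compound 2 has no single number, so no step between compound 2 and compound 4 can be read. The compounds shown leave open what 2,4-dichlorophenyl in place of 4-nitrophenyl does on the shared core. No supporting measurement bears on this result.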